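Swapping Trifluoromethyl for Methylcarbamoyl: One Change, One Expectation

The source may hold more compounds than are shown below. What is called first, only, known or untested is meant among the compounds shown, and "the series" means these compounds.

Of the compounds shown here, three share a common core and have been tested in an assay for inhibition of Indoleamine 2,3-dioxygenase 1 (Homo sapiens), with stated times of 10 min and 60 min, tested at 10 uM; on this read-out lower numbers stand for a weaker effect and higher numbers for a stronger effect at the one concentration tested. Compound 1 `COc1cc(CNc2cc(Br)cc3[nH]ncc23)c([N+](=O)[O-])cc1OC` gives 48%, and compound 3 `O=[N+](O)c1c(Cl)cccc1CNc1cc(C(F)(F)F)cc2[nH]ncc12` gives 45%. Compound 2 `FC(F)(F)c1cccc(CNc2cc(C(F)(F)F)cc3[nH]ncc23)c1` gives 25%, the lowest of the three, with both other numbers higher by more than the usual scatter. Compound 4 `CNC(=O)c1cccc(CNc2cc(C(F)(F)F)cc3[nH]ncc23)c1` differs from compound 2 in a single place: methylcarbamoyl in place of trifluoromethyl on an aromatic carbon. Within the data shown here, no measured pair shows this kind of change, so the size of its effect is unknown. The expected step of a number 5 percentage points higher from compound 2 to compound 4 (within the scatter) is small, upward, and likely within the scatter. Compound 4 is therefore expected to give about 30%, with a plausible range from 10% to 55%.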

Compound 4, a percentage reported as inhibition, at one concentration (the size of the read-out at that concentration, not a potency): 33%
The estimate for compound 4 lay 3 percentage points below the measured number, within the range that was stated.
By their numbers in this assay, from the lowest: compounds 2 and 4 (each within the scatter of the next); then compounds 3 and 1 (each within the scatter of the next).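

Swapping trifluoromethyl for methylcarbamoyl on this aromatic carbon, meta to a large group, gives a number 8 percentage points higher from compound 2 to compound 4 (within the scatter) in this assay, so the two compounds cannot be told apart on this read-out. This position therefore takes a group with one hydrogen-bond donor and one hydrogen-bond acceptor in place of one with neither, and the number stays within the usual scatter.

Going by these compounds, whether a carboxylic acid, an amine or a longer amide chain at this position would move the number beyond the scatter remains open. No measurement shown here gives a reason for this result.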